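The compounds below may be only part of what the source reports. "The series", "measured", "known", "first", "only" and "open" are said of these compounds alone.

Measured so far in the series:

compound 1, `CCn1c(SCC(=O)Nc2ccc(/C(C)=N/O)cc2)nnc1-c1cc(OC)c(OC)c(OC)c1`: 70%
compound 2, `CCn1c(SCC(=O)Nc2ccc(C(C)=O)cc2)nnc1-c1ccc(OC)c(OC)c1`: 69%

In a functional assay on the whole organism (strain albino) for inhibition, with Rattus norvegicus as the target, read by paw edema, with stated times of 30 min and 4 h, at a dose of 0.28 mmol/kg by the oral route (a lower number here means less inhibition, a higher number more inhibition at the dose given (going by the name of the read-out)), compound 1 gives 70%. Compound 2 gives 69% in the same test. Compound 2 thus holds the lower of the two numbers in hand, but its gap to compound 1 is within the usual scatter, so the two cannot be ranked against each other. Among the compounds with values here, compound 1 and compound 2 differ from one another in more than one place, so no single step between measured compounds is available to calibrate any change.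

Compound 3, `CCn1c(SCC(=O)Nc2ccc(C(C)=O)cc2)nnc1-c1cc(OC)c(OC)c(OC)c1`, is not yet measured. It differs from compound 2 in one place: methoxy in place of hydrogen on an aromatic carbon. Compound 1 carries the same methoxy pattern as compound 3 but differs elsewhere as well, so its value gives only a loose hint that this pattern sits in the same range. On that basis the step in this assay is expected to be small, in no particular direction, and not beyond the scatter.

Compound 3 is expected to give about 70%, in a range from 58% to 80%. The expected step is then a number 1 percentage points higher from compound 2 to compound 3 (within the scatter).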

Compound 3, a percentage reported as inhibition, in the whole organism at one dose (the size of the read-out at that dose, not a potency): 68%
Estimate against measurement, compound 3: 2 percentage points above; low and high end bracket the measured number.
By their numbers in this assay, from the lowest: compounds 3, 2 and 1 (each within the scatter of the next).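

In this assay methoxy in place of hydrogen on an aromatic carbon, ortho to a methoxy group and meta to a large group, gives a number 1 percentage points lower from compound 2 to compound 3 (within the scatter) and so makes no readable difference at this position at the dose given. Within the data shown here, the first step at the other changed site, the ketone group of compound 3 in place of the oxime group of compound 1, gives a number 2 percentage points lower from compound 1 to compound 3 (within the scatter) and so separates the two groups no better than the scatter allows. Nothing on hand explains why either change leaves the read-out within the scatter.

Every change seen so far therefore stays within the scatter, and the readings at one dose say nothing about whether the compounds differ in potency. Still open, as far as these compounds go, is whether an amine or a carboxylic acid in place of the added methoxy, or a longer chain in place of the ethyl group on the shared core, would produce a step beyond the scatter.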